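The compounds below may be only part of what the source reports. "The series", "measured", "known", "first", "only" and "open" are said of these compounds alone.

Of the compounds shown here, three of one series have been measured in a functional assay on PANC-1 cells (Homo sapiens) for inhibition, read by MTT assay, with a stated time of 24 h, tested at 10 uM; on this read-out higher numbers stand for more inhibition at the one concentration tested (going by the name of the read-out) and lower numbers for less inhibition. Compound 1, `CC(C)=CCC1Cc2c(OC(=O)Nc3ccc(Cl)cc3)cc(=O)n(CCCO)c2CC1(C)C`, gives 49.8% in this assay. Compound 2, `CC(C)=CCC/C(C)=C/CC1Cc2c(OC(=O)Nc3cccc(F)c3)cc(=O)n(CCCO)c2CC1(C)C`, gives 52.3%. Compound 3, `CC(C)=CCC/C(C)=C/CC1Cc2c(OC(=O)Nc3ccccc3F)cc(=O)n(CCCO)c2CC1(C)C`, gives 71.6%, the highest of the three numbers, standing beyond the usual scatter above both others. For the measured compounds named here, the one measured step that involves it, a number 19.3 percentage points higher from compound 2 to compound 3 (beyond the scatter), shows that moving a single fluorine around the ring on the amide-type nitrogen can shift the read-out by a modest but real amount.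

Compound 4, `CC(C)=CCC/C(C)=C/CC1Cc2c(OC(=O)Nc3ccc(Cl)cc3)cc(=O)n(CCCO)c2CC1(C)C`, is still to be measured. Its difference from compound 3 is 4-chlorophenyl in place of 2-fluorophenyl on an amide-type nitrogen. Going by the values given here, no measured step covers this exact change. Compound 1 carries the same 4-chlorophenyl group on its amide-type nitrogen, though the rest of its structure is not identical to compound 4, and its value sits well below that of compound 3. Taken together with the sensitivity seen in the step from compound 2 to compound 3, this suggests that compound 4 is expected to fall back toward the level of compounds 1 and 2, giving an expected step of a number 19.6 percentage points lower from compound 3 to compound 4 (beyond the scatter). Compound 4 is therefore estimated at 52%, with a likely range from 38% to 66%.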

Compound 4, a percentage reported as inhibition, at one concentration (the size of the read-out at that concentration, not a potency): 47.2%
The estimate for compound 4 lay 4.8 percentage points above the measured number; low and high end bracket the measured number.
By their numbers in this assay, from the lowest: compounds 4, 1 and 2 (each within the scatter of the next); then compound 3.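

In this assay the swap to 4-chlorophenyl from 2-fluorophenyl on the amide-type nitrogen gives a number 24.4 percentage points lower from compound 3 to compound 4 (beyond the scatter) while the swap to 4-chlorophenyl from 3-fluorophenyl gives a number 5.1 percentage points lower from compound 2 to compound 4 (within the scatter) and so, with the rest of the molecule unchanged, only the 2-fluorophenyl compound stands apart. For the compounds shown here, compound 4 also gives the first clean comparison at a second place: with 4-chlorophenyl held fixed, 3-methylbut-2-en-1-yl in place of hydrogen on a saturated chain carbon bound to a double-bonded chain carbon gives a number 2.6 percentage points lower from compound 1 to compound 4 (within the scatter) and so this change in the chain makes no readable difference for this pair. No independent measurement is available to explain why the 2-fluorophenyl compound separates from the others.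

A 2-chlorophenyl or a 4-fluorophenyl group on the same nitrogen would help show whether the higher number follows the fluorine, its place on the ring, or both, and an unsubstituted phenyl group would provide a plain reference point. Going by these compounds, it also remains open whether 2-fluorophenyl would give the same high reading on the shorter-chain core of compound 1, since the chain comparison here covers only 4-chlorophenyl.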